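Adding a Bromo to the Core of Compound 2

The source may hold more compounds than are shown below. What is called first, only, known or untested is meant among the compounds shown, and "the series" means these compounds.

Measured in a functional assay on OVCAR-8 cells (Homo sapiens); on this read-out lower numbers stand for stronger inhibition of growth and higher numbers for weaker inhibition of growth:
- Compound 1 `O=S(=O)(/C=C/c1ccc(Br)cc1)Cc1ccc(Nc2ncnc3ccccc23)cc1`: 38000 nM
- Compound 2 `O=S(=O)(/C=C/c1ccc(Cl)cc1)Cc1ccc(Nc2ncnc3ccccc23)cc1`: > 100000 nM
- Compound 3 `O=S(=O)(/C=C/c1ccc(F)cc1Cl)Cc1ccc(Nc2ncnc3ccccc23)cc1`: 100000 nM

Compound 2 gives > 100000 nM, which is a limit of the assay and not a number. Compound 4 `O=S(=O)(/C=C/c1ccc(Cl)cc1)Cc1ccc(Nc2ncnc3ccc(Br)cc23)cc1` keeps everything in compound 2 but gains one group on the shared core: bromo in place of hydrogen on an aromatic carbon. The new bromo sits on an aromatic carbon of a six-membered aromatic ring of carbon only, part of a fused or bridged system of two rings.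

Within the data shown here, no measured step adds a group at that place, so the evidence is indirect. Two steps remove a bromo elsewhere in the molecule. Chloro in place of bromo gives an at least 2.6-fold higher number from compound 1 to compound 2 (0.42 log units; beyond the scatter), and 2-chloro-4-fluorophenyl in place of 4-bromophenyl gives a 2.6-fold higher number from compound 1 to compound 3 (0.42 log units; beyond the scatter). Both are modest and both raise the number, so a bromo on the core may lower it by a similarly modest amount.

The expected change is an at least 1.6-fold lower number from compound 2 to compound 4 (0.22 log units; that floor lies within the scatter). For compound 4 the estimate is 60000 nM, with an expected range of 20000 nM to 200000 nM.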

Compound 4, concentration for 50% growth inhibition: 3000 nM
Estimate against measurement, compound 4: 20-fold (1.30 log units) above; the measured number lies below the stated range.
By their numbers in this assay, from the lowest: compound 4; then compound 1; then compound 3.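

Compound 2 stands at a limit of the assay and not a number: the limit of > 100000 nM in this assay, at which 1 of the 4 values shown sits. Even so, in this assay a single bromo in place of hydrogen on an aromatic carbon of the shared core gives an at least 33-fold lower number from compound 2 to compound 4 (1.52 log units; beyond the scatter), so the true size of the step may be greater still. Among these compounds, the earlier compounds differ only away from the core, with modest steps such as a 2.6-fold higher number from compound 1 to compound 3 (0.42 log units; beyond the scatter), and this result is the first to show that growth inhibition can respond far more strongly to a change on the core.

The compounds shown leave open whether this gain belongs to bromo itself or would also come with another group at this place, such as chloro, methoxy or an amine. They also leave open whether the same core bromo would lower the number as far when paired with the 4-bromophenyl of compound 1.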